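The source may report more compounds than this note shows. Statements on the series, on what has been measured and on what is new or still open speak of the compounds shown alone.

Within the data shown here, compound 2, `Cc1c(Cl)cccc1Oc1cccn2c(C3CCOCC3)nnc12`, stands at the top of the two numbers so far in an ADME assay on microsomes from liver (Mus musculus) for metabolic stability, with a stated time of 10 min (a lower number here means that less of the compound is left, a higher number that more of the compound is left), where compound 2 gives 100%. Its nearest neighbour is compound 1, `Cc1c(Cl)cccc1Oc1cccn2c(C34CCC(CC3)C4)nnc12`, and in this assay compound 1 gives 57%. Among the measured compounds shown here, the one measured step between the pair is a number 43 percentage points higher from compound 1 to compound 2 (beyond the scatter).

Compound 3, `Cc1c(Cl)cccc1Oc1cccn2c(C34CCC(O)(CC3)CC4)nnc12`, differs from compound 2 in one place: a group of 9 heavy atoms (8 carbon, 1 oxygen; 2 six-membered non-aromatic rings of carbon only) in place of a group of 6 heavy atoms (5 carbon, 1 oxygen; one six-membered non-aromatic ring with 1 hetero atom), on an aromatic carbon. This change bears on the same position that the step from compound 1 to compound 2 touched, and it goes part of the way back in the same direction, since two non-aromatic rings of carbon only return in place of the six-membered ring with one hetero atom, while one hydrogen-bond donor is added. For the measured compounds named here, the only guide is compound 1, whose value 57% lies well under that of compound 2 because of a number 43 percentage points higher from compound 1 to compound 2 (beyond the scatter), so a drop beyond the scatter is expected for compound 3, though smaller than the full step, given the oxygen that stays. The expected step is a number 22 percentage points lower from compound 2 to compound 3 (beyond the scatter), and compound 3 is estimated at 78%, with a range from 50% to 100%.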

Compound 3, percent of the compound remaining: 96%
Beside the measured number, compound 3's estimate is 18 percentage points below it, and the stated range covers the measured number.
By their numbers in this assay, from the lowest: compound 1; then compounds 3 and 2 (each within the scatter of the next).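

In this assay, the step of a number 4 percentage points lower from compound 2 to compound 3 (within the scatter) shows that, on this aromatic carbon between two ring nitrogen atoms, the oxan-4-yl group can give way to a larger group of two six-membered carbon rings with one hydrogen-bond donor without a change that stands out from the scatter. Carbon-only rings at this place therefore do not by themselves go with the low number of compound 1: the step of a number 39 percentage points higher from compound 1 to compound 3 (beyond the scatter) is large and separates two groups that both have two carbon-only rings, though of different ring size and with a hydrogen-bond donor only in the group of compound 3. Nothing at hand bears on why these groups fall as they do.

The compounds shown leave open how much of this result belongs to the hydroxyl group and how much to the six-membered ring pair, for the two occur here only together. They also leave open whether the same ring pair would hold its place in this read-out with an amine or a carboxylic acid where the hydroxyl group stands.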